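From 2-chlorophenyl to 4-bromophenyl: half-life notes

A few compounds are considered here, and "the series" means these few. Any claim that something is new, unique, unknown or untested is made for them only; others in the source may bear on it.

In a physicochemical assay for pharmacokinetics (on this read-out lower numbers stand for a shorter-lived compound and higher numbers for a longer-lived compound), compound 3 `O=C(NCc1ccccc1Cl)N1C(=O)c2ccccc2S1(=O)=O` gives 0.42 h, within the scatter of both other measured values. Compound 1 `O=C(NCc1ccccc1F)N1C(=O)c2ccccc2S1(=O)=O` gives 0.598 h and compound 2 `O=C(NCc1ccc(C(F)(F)F)cc1)N1C(=O)c2ccccc2S1(=O)=O` gives 0.212 h, so those two stand further apart from each other.

Compound 4 `O=C(NCc1ccc(Br)cc1)N1C(=O)c2ccccc2S1(=O)=O` has not been measured. Its difference from compound 3 is 4-bromophenyl in place of 2-chlorophenyl on a saturated chain carbon bound to an amide-type nitrogen.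

For the measured compounds named here, one measured step bears on this: a 1.4-fold lower number from compound 1 to compound 3 (0.15 log units; within the scatter), for chloro in place of fluoro on an aromatic carbon. Going by the values given here, it exchanges one halogen for another, yet no measured step covers the full change made here. Compound 2, at 0.212 h, is the nearest measured structure to compound 4, which pulls the expectation towards the low side of this assay.

The expected step is a 1.4-fold lower number from compound 3 to compound 4 (0.15 log units; within the scatter), with no move beyond the scatter anticipated. The estimate for compound 4 is 0.3 h, with an expected range of 0.17 h to 0.52 h.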

Compound 4, half-life: 0.187 h
The estimate for compound 4 lay 1.6-fold (0.21 log units) above the measured number; the range from low to high includes it.
By their numbers in this assay, from the lowest: compounds 4, 2, 3 and 1 (each within the scatter of the next, the first and the last beyond it).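

At this position, on a saturated chain carbon bound to an amide-type nitrogen, replacing the aryl group can shift the number in this assay beyond the scatter: 4-bromophenyl in place of 2-chlorophenyl gives a 2.2-fold lower number from compound 3 to compound 4 (0.35 log units; beyond the scatter), and 4-bromophenyl in place of 2-fluorophenyl gives a 3.2-fold lower number from compound 1 to compound 4 (0.50 log units; beyond the scatter). By contrast, bromo in place of trifluoromethyl on an aromatic carbon gives a 1.1-fold lower number from compound 2 to compound 4 (0.05 log units; within the scatter), so this exchange leaves the number within the scatter. No measurement at hand accounts for either larger step.

Going by these compounds, the steps to compound 4 change the halogen and its place together, so 4-chlorophenyl and 2-bromophenyl remain open as the groups that could separate the two changes. Also open, on these data alone, is how the number would respond to a phenyl ring carrying an amine or a carboxylic acid.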